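A Phenyl Halogen Swap on a Weakly Active Pair

The source may hold more compounds than are shown below. What is called first, only, known or untested is meant among the compounds shown, and "the series" means these compounds.

Three compounds have numbers in a functional assay on HepG2 cells (Homo sapiens) for antiproliferative activity, read by MTT assay, with a stated time of 72 h; on this read-out higher numbers stand for weaker inhibition and lower numbers for stronger inhibition. Compound 1 `Cc1nn(C)c(Oc2cccc(F)c2)c1/C=N\CCCCCOc1cc2oc(=O)cc(C)c2cc1Cl` gives 13400 nM in this assay. Compound 2 `Cc1nn(C)c(Oc2ccc(Br)cc2)c1/C=N\CCCCCOc1cc2oc(=O)cc(C)c2cc1Cl` gives 13800 nM. These two differ in one place, and the step of a 1.0-fold higher number from compound 1 to compound 2 (0.01 log units; within the scatter) shows that exchanging one halogenated phenyl for another on this oxygen moved the reading by nothing beyond the usual scatter. Compound 3 `Cc1nn(C)c(Oc2cccc(F)c2)c1/C=N\CCCCCCOc1cc2oc(=O)cc(C)c2cc1Cl` gives > 25000 nM in this assay, which is a limit of the assay rather than a number. Compound 3 therefore sits at the limit of > 25000 nM in this assay, at which 1 of the 3 values shown sits, so its true value is known only as a range.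

Compound 4 `Cc1nn(C)c(Oc2ccc(I)cc2)c1/C=N\CCCCCCOc1cc2oc(=O)cc(C)c2cc1Cl` has not yet been measured. It differs from compound 3 in one place: 4-iodophenyl in place of 3-fluorophenyl on an oxygen on an aromatic ring. Among the compounds with values here, the one measured step that bears on this kind of change is a 1.0-fold higher number from compound 1 to compound 2 (0.01 log units; within the scatter), which was within the scatter. A halogen swap on the phenyl ether is thus expected to give no step beyond the scatter here either, and compound 4 is expected to remain at or near the limit where compound 3 stands. The estimate for compound 4 is 30000 nM, with a range from 15000 nM to 60000 nM. This estimate means an expected step that the limit leaves unreadable from compound 3 to compound 4.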

Compound 4, half-maximal inhibitory concentration: 14200 nM
Compound 4: middle estimate off by 2.1-fold (0.32 log units), on the high side, outside the stated range (below it).
By their numbers in this assay, from the lowest: compounds 1, 2 and 4 (each within the scatter of the next). At a limit, above all of these: compound 3.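

Where the earlier swap of one halogenated phenyl for another stayed within the scatter, this pair, on its own chain, gives an at least 1.7-fold lower number from compound 3 to compound 4 (0.24 log units; that floor lies within the scatter) in this assay. Compound 3 has no exact reading, only a limit of the assay: the limit of > 25000 nM in this assay, at which 1 of the 4 values shown sits. Within the data shown here, the printed step is therefore a floor, so the true change may be no larger than ordinary scatter or may be much larger, and the new finding is only that compound 4 gives a readable number on this chain where compound 3 gave none.

The swap from 3-fluorophenyl to 4-iodophenyl alters both the halogen and where it sits on the ring, so the compounds shown cannot tell which of the two matters, or whether either does. They also leave open how this oxygen-linked ring would read with no halogen at all, or with an amine or a carboxylic acid on it, and whether any such group would move the reading clearly beyond the scatter on either chain.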